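A few compounds are considered here, and "the series" means these few. Any claim that something is new, unique, unknown or untested is made for them only; others in the source may bear on it.

Among the measured compounds shown here, compound 3 `CCN(CC)CCCNc1nc(-c2ccc(NC(=O)Nc3ccc(Cl)cc3)cc2)nc2c(Cl)c(Cl)sc12` gives 660 nM in a functional assay on MDA-MB-231 cells (Homo sapiens) for cytotoxicity, read by MTT assay, with a stated time of 72 h (a lower number here means a stronger inhibitor, a higher number a weaker inhibitor), the lowest of the three numbers measured so far. Compound 1 `CN(C)CCCNc1nc(-c2ccc(NC(=O)Nc3ccc(Cl)cc3Cl)cc2)nc2c(Cl)c(Cl)sc12` gives 3490 nM in this assay, and compound 2 `CN(C)CCNc1nc(-c2ccc(NC(=O)Nc3ccc(Cl)cc3Cl)cc2)nc2c(Cl)c(Cl)sc12` gives 3500 nM. For the measured compounds named here, the only single-point step among the measured compounds, a 1.0-fold higher number from compound 1 to compound 2 (0.00 log units; within the scatter), concerns the amine chain rather than the aromatic ring. Compound 4 `CCN(CC)CCCNc1nc(-c2ccc(NC(=O)Nc3ccc(Cl)cc3Cl)cc2)nc2c(Cl)c(Cl)sc12` differs from compound 3 in one place: chloro in place of hydrogen on an aromatic carbon, on an aromatic carbon ortho to a large group and meta to a chloro group. Going by the values given here, no measured pair isolates this change. Compounds 1 and 2 carry the same 2,4-dichlorophenyl as compound 4, but they also differ from compound 3 in the amine chain, so their higher numbers cannot be credited to the added chloro alone. The expectation is therefore loose: the number for compound 4 is expected to lie near or somewhat above that of compound 3, an expected step of a 2.3-fold higher number from compound 3 to compound 4 (0.36 log units; beyond the scatter). The estimate for compound 4 in this assay is 1500 nM, expected to fall between 500 nM and 5000 nM.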

Compound 4, half-maximal inhibitory concentration: 3940 nM
For compound 4 the middle estimate is 2.6-fold (0.42 log units) below the measured one; low and high end bracket the measured number.
By their numbers in this assay, from the lowest: compound 3; then compounds 1, 2 and 4 (each within the scatter of the next).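

In this assay the change from 4-chlorophenyl to 2,4-dichlorophenyl can now be read on its own: a 6.0-fold higher number from compound 3 to compound 4 (0.78 log units; beyond the scatter), so one chloro on an aromatic carbon ortho to a large group is enough to weaken the compound. With 2,4-dichlorophenyl in place, the amine chain makes no clear difference in these pairs: a 1.1-fold higher number from compound 1 to compound 4 (0.05 log units; within the scatter) for diethylamino in place of dimethylamino, and a 1.1-fold higher number from compound 2 to compound 4 (0.05 log units; within the scatter) for (diethylamino)methyl in place of dimethylamino. Nothing measured here explains the effect of the added chloro.

As far as these compounds go, what a fluoro or a methyl group would do on this same aromatic carbon remains open. Also open, from the compounds shown here alone, is how a dimethylamino chain would behave with the 4-chlorophenyl group, which appears here only with the diethylamino chain of compound 3.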